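This account rests on a few compounds, and the source may have more. Where it says the series, first, only, none or still open, it means among the compounds named here.

Measured compounds:
compound 1, `COc1ccc([C@@H]2CC(=O)c3c(O)cc(OCc4cn(CC5CC5)nn4)cc3O2)cc1O`, 11900 nM
compound 2, `COc1ccc([C@@H]2CC(=O)c3c(O)cc(OCc4cn(Cc5ccccc5Cl)nn4)cc3O2)cc1O`, 6140 nM
compound 3, `COc1ccc([C@@H]2C/C(=N\O)c3c(O)cc(OCc4cn(CC5CC5)nn4)cc3O2)cc1O`, 6320 nM

In a functional assay on RAW264.7 cells (Mus musculus) for inhibition, read by Griess assay, with stated times of 2 h and 24 h (a lower number here means a stronger inhibitor, a higher number a weaker inhibitor), compound 1 gives 11900 nM and compound 2 gives 6140 nM. The change between them is 2-chlorophenyl in place of cyclopropyl on a saturated chain carbon bound to an aromatic nitrogen, and the step it made is a 1.9-fold lower number from compound 1 to compound 2 (0.29 log units; within the scatter). Compound 3 shares the triazole substituent of compound 1 but sits on a different core; the difference between the two cores is not broken down here. In this assay compound 3 gives 6320 nM.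

Compound 4, `COc1ccc([C@@H]2C/C(=N\O)c3c(O)cc(OCc4cn(Cc5ccccc5Cl)nn4)cc3O2)cc1O`, has not yet been measured in this assay. It differs from compound 3 by 2-chlorophenyl in place of cyclopropyl on a saturated chain carbon bound to an aromatic nitrogen, the same change as that from compound 1 to compound 2, made on the core of compound 3. Since the earlier step, a 1.9-fold lower number from compound 1 to compound 2 (0.29 log units; within the scatter), stayed within the scatter, the expected step here is a 1.8-fold lower number from compound 3 to compound 4 (0.26 log units; within the scatter), resting only on that single precedent. For compound 4 the estimated value in this assay is 3500 nM, with an expected range from 1500 nM to 8500 nM.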

Compound 4, half-maximal inhibitory concentration: 13400 nM
For compound 4 the middle estimate is 3.8-fold (0.58 log units) below the measured one; measured number above the stated range.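

In this assay the exchange of cyclopropylmethyl for 2-chlorobenzyl did not carry over from one core to the other, and the two steps differ: the same change on two cores in this assay, a 1.9-fold lower number (0.29 log units; within the scatter) from compound 1 to compound 2 and a 2.1-fold higher number (0.33 log units; beyond the scatter) from compound 3 to compound 4, 4.1-fold (0.61 log units) apart, beyond the scatter of two such steps

On the core of compound 3 the change gives a 2.1-fold higher number from compound 3 to compound 4 (0.33 log units; beyond the scatter), a modest step, while on the core of compound 1 the same change stayed within the scatter. So in this series a step seen on one core could not be relied on for the other, but with a single pair on each core this does not establish a general reversal of direction or say what lies behind the difference.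

As far as these compounds go, it remains open whether other groups on the saturated chain carbon bound to an aromatic nitrogen, such as an unsubstituted phenyl, a longer alkyl chain or an amine, would also depend on the core. From the compounds shown here alone, whether the difference between the two cores holds beyond these four compounds also remains open.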